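Replacing the nitrophenyl arm of an isomerase inhibitor

This account rests on a few compounds, and the source may have more. Where it says the series, first, only, none or still open, it means among the compounds named here.

Of the compounds shown here, three have so far been tested in an assay for inhibition of protein disulfide-isomerase (Homo sapiens), with a stated time of 1 h; a higher number here means a weaker inhibitor, a lower number a stronger inhibitor. Compound 1 `O=[N+]([O-])c1ccc(C(c2c(O)ccc3[nH]ncc23)N2CCCCC2)cc1` gives 520 nM. Compound 2 `Cc1ccnc(NC(c2ccc([N+](=O)[O-])cc2)c2ccc3cccnc3c2O)c1` gives 530 nM. Compound 3 `Oc1cc(F)ccc1C(c1ccc2ccoc2c1O)N1CCCCC1` gives 1070 nM. Among these three numbers compound 2 stands second highest: its nearest neighbour is compound 1, whose value lies within the usual scatter of its own, while its furthest neighbour is compound 3, whose higher number lies beyond the scatter. Compound 1 and compound 2 share the 4-nitrophenyl group on the saturated chain carbon; compound 3 does not.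

Compound 4 `COc1ccc(C(Nc2cc(C)ccn2)c2ccc3cccnc3c2O)cc1O` has not yet been measured. It differs from compound 2 in a single place: 3-hydroxy-4-methoxyphenyl in place of 4-nitrophenyl on a saturated chain carbon bound to an aromatic carbon and a nitrogen on an aromatic ring. For the measured compounds named here, no pair of measured compounds isolates this exchange, so the size of the step cannot be read from the data directly. Going by the values given here, the only hint is that compound 3, the one compound without a 4-nitrophenyl group, gives 1070 nM. On that thin basis a mild weakening is expected for compound 4, close to the edge of the scatter, giving an expected step of a 1.7-fold higher number from compound 2 to compound 4 (0.23 log units; within the scatter). Compound 4 is therefore estimated to give about 900 nM, with a plausible range from 350 nM to 2500 nM.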

Compound 4, half-maximal inhibitory concentration: 150 nM
Estimate against measurement, compound 4: 6.0-fold (0.78 log units) above; measured number below the stated range.
By their numbers in this assay, from the lowest: compound 4; then compounds 1 and 2 (each within the scatter of the next); then compound 3.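

In this assay, for the compounds shown here, putting 3-hydroxy-4-methoxyphenyl in place of 4-nitrophenyl on the saturated chain carbon bound to an aromatic carbon and a nitrogen on an aromatic ring gives a 3.5-fold lower number from compound 2 to compound 4 (0.55 log units; beyond the scatter), the first step in this set that isolates a single change, and it shows that the 4-nitrophenyl group is not required for inhibition on this core and can be replaced with a gain. The two groups match in their heavy-atom count and in their single six-membered aromatic ring of carbon only, while the entering group carries a hydrogen-bond donor that the leaving group lacks and has no nitrogen, but the hydroxy and methoxy groups arrive together, so this one step cannot divide the gain between them. Nothing measured here gives a reason for the step.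

The compounds shown leave open whether 3-hydroxyphenyl alone, 4-methoxyphenyl alone or an unsubstituted phenyl would match compound 4 at this position. They also leave open whether the same exchange would carry over to the core of compound 1, which has a piperidine in place of the aminopyridine.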